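The compounds below may be only part of what the source reports. "The series", "measured", "known", "first", "only" and "open" are said of these compounds alone.

Of the compounds shown here, two built on one shared core have been measured in a functional assay on MCF7 cells (Homo sapiens) for cytotoxicity, read by sulforhodamine B assay, with a stated time of 48 h; a lower number here means a stronger inhibitor of growth, a higher number a weaker inhibitor of growth. Compound 2 `CN(C)CN1C(=O)C(=O)c2ccccc21` carries a hydrogen on the aromatic carbon in question, and in this assay compound 2 gives 40500 nM. Compound 1 `CN(C)CN1C(=O)C(=O)c2c(Br)cccc21` carries a bromo group on that carbon instead, and in this assay compound 1 gives 57600 nM. Compound 2 stands nearest to compound 1, and the measured step between them is a 1.4-fold lower number from compound 1 to compound 2 (0.15 log units; within the scatter), so the two compounds cannot be told apart on these numbers.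

Compound 3 `CN(C)CN1C(=O)C(=O)c2c(Cl)cccc21` has not yet been measured. It differs from compound 2 by chloro in place of hydrogen on an aromatic carbon. Within the data shown here, the only measured step that bears on this change is the exchange of bromo for hydrogen, which gave a 1.4-fold lower number from compound 1 to compound 2 (0.15 log units; within the scatter); that swap left the number inside the scatter. A chloro group placed on the same aromatic carbon is therefore expected to keep the number in this assay close to where compound 2 stands, with no step beyond the scatter in either direction. The expected step is a 1.2-fold higher number from compound 2 to compound 3 (0.07 log units; within the scatter). Compound 3 is estimated at 48000 nM, with a range from 20000 nM to 115000 nM.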

Compound 3, concentration for 50% growth inhibition: 87800 nM
For compound 3 the middle estimate is 1.8-fold (0.26 log units) below the measured one; the range from low to high includes it.
By their numbers in this assay, from the lowest: compounds 2, 1 and 3 (each within the scatter of the next, the first and the last beyond it).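

In this assay, among these compounds, chloro in place of hydrogen on this aromatic carbon gives the first step at this position that clears the scatter: a 2.2-fold higher number from compound 2 to compound 3 (0.34 log units; beyond the scatter). This shows that a single added atom here can move the number towards weaker growth inhibition, though only modestly, while the bromo of compound 1 stays within the scatter of the hydrogen of compound 2. The two halogens themselves cannot be separated, with a 1.5-fold higher number from compound 1 to compound 3 (0.18 log units; within the scatter), so the small gap between the chloro and bromo steps is no firm sign of a difference between these two groups, and nothing measured here accounts for the chloro step.

The compounds shown leave open whether a group of another kind on this carbon, such as an amine, a methoxy group or a carboxylic acid, would shift the number in either direction, and whether fluoro would sit with chloro and bromo. They also leave open whether chloro on another carbon of the same six-membered ring would give a step of similar size, or any step beyond the scatter at all.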